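Methylsulfonyl in Place of (Phenoxymethyl)carbonyl on Compound 3

This account rests on a few compounds, and the source may have more. Where it says the series, first, only, none or still open, it means among the compounds named here.

Values so far in an ADME assay on microsomes from liver (Homo sapiens) for metabolic stability, read by LC-MS, with NADPH named in the record, with a stated time of 60 min, tested at 1 uM, in the absence of a further agent (on this read-out higher numbers stand for a more stable compound and lower numbers for a less stable compound), for three compounds:
- Compound 1 `COc1ccc(-c2c(C)oc3c(N4CC[C@@H](NC(C)=O)C4)cc(C)nc23)cc1OC` gives > 95% as a limit
- Compound 2 `COc1ccc(-c2c(C)nc3c(N4CC[C@@H](NC(C)=O)C4)cc(Cl)nn23)cc1OC` gives > 95% as a limit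
- Compound 3 `COc1ccc(-c2c(C)nc3c(N4CC[C@@H](NC(=O)COc5ccccc5)C4)cc(C)nn23)cc1OC` gives > 95% as a limit

Compound 3 stands at > 95% in this assay, which is a limit and not a number. It shares this position with the other two compounds (the limit of > 95% in this assay, at which 3 of the 3 values shown sit). Compound 4 `COc1ccc(-c2c(C)nc3c(N4CC[C@@H](NS(C)(=O)=O)C4)cc(C)nn23)cc1OC` has not yet been measured. It carries methylsulfonyl in place of (phenoxymethyl)carbonyl on an amine nitrogen. Among the measured compounds shown here, no two measured compounds differ in one place, so the expectation rests only on that shared limit. The expected step of a number at least 3 percentage points lower from compound 3 to compound 4 (that floor lies within the scatter) is none beyond the usual scatter. For compound 4 the estimated value is 92% with an expected range from 75% to 100% in this assay for now.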

Compound 4, percent of the compound remaining: > 95%
Compound 4: a limit, no number; the forecaster's own chance of this, stated with the estimate: 55%; middle value at least 3 percentage points from the limit.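

Compound 3 and compound 4 both stand at a limit and not a number, so no step between them can be read in this assay: the limit of > 95% in this assay, at which 4 of the 4 values shown sit.

The compounds shown leave open whether methylsulfonyl in place of (phenoxymethyl)carbonyl changes anything in this assay.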